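Side-chain exchange on the shared core: compound 4 pending

The source may hold more compounds than are shown below. What is called first, only, known or untested is meant among the compounds shown, and "the series" means these compounds.

Compound 3 `CCCCCCCCCCc1ccc(-c2noc([C@@H](N)CCCCN)n2)cc1` stands at the upper end of the three numbers in an assay on HeLa cells for inhibition of sphingosine-1-phosphate transporter SPNS2 (Mus musculus), read by LC-MS, tested at 2 uM (a higher number here means more inhibition at the concentration tested (going by the name of the read-out), a lower number less inhibition), where compound 3 gives 43%; it is indistinguishable from compound 1 and well above compound 2. Compound 1 `CCCCCCCCCCc1ccc(-c2noc(CC3CCNC3)n2)cc1` gives 44%, and compound 2 `CCCCCCCCCCc1ccc(-c2noc(C(Cl)CCN)n2)cc1` gives 5%. The change to compound 4 `CCCCCCCCCCc1ccc(-c2noc(CC(O)CN3CCCC3)n2)cc1` is 2-hydroxy-3-(pyrrolidin-1-yl)propyl in place of 1,5-diaminopentyl on an aromatic carbon. Among the compounds with values here, two measured steps bear on this. The step of a number 1 percentage points lower from compound 1 to compound 3 (within the scatter) shows that swapping (pyrrolidin-3-yl)methyl for 1,5-diaminopentyl made no difference beyond the scatter. The step of a number 38 percentage points higher from compound 2 to compound 3 (beyond the scatter) shows a large loss when the chain bore chlorine and was shorter. Compound 4 returns a five-membered ring with one nitrogen, so a step of about a number 8 percentage points lower from compound 3 to compound 4 (within the scatter) is expected, within the scatter or a small loss. Compound 4 is therefore estimated at 35%, between 15% and 55%.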

Compound 4, a percentage reported as inhibition, at one concentration (the size of the read-out at that concentration, not a potency): 21%
Beside the measured number, compound 4's estimate is 14 percentage points above it, and the stated range covers the measured number.
By their numbers in this assay, from the lowest: compound 2; then compound 4; then compounds 3 and 1 (each within the scatter of the next).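

In this assay the change to 2-hydroxy-3-(pyrrolidin-1-yl)propyl gives a number 22 percentage points lower from compound 3 to compound 4 (beyond the scatter) and also a number 23 percentage points lower from compound 1 to compound 4 (beyond the scatter), so a five-membered ring with one nitrogen does not by itself hold the level of the two higher compounds. The same side chain still gives a number 16 percentage points higher from compound 2 to compound 4 (beyond the scatter), which places it in an intermediate position among the side chains at this aromatic carbon. No measured evidence bears on the reason for this ordering. Open, on these data alone, is whether the hydroxyl group or the pyrrolidin-1-yl attachment matters more. Also open, as far as these compounds go, is how a carboxylic acid or a piperidine ring would fare on this chain.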